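Flavanone-free notes: benzylamine to diethylamine on the shared core

The source may report more compounds than this note shows. Statements on the series, on what has been measured and on what is new or still open speak of the compounds shown alone.

Measured so far:
compound 1, `COc1cc2c(cc1OC)C(=O)/C(=C/c1ccc(CN(C)Cc3ccccc3)c(O)c1)O2`: 17.8%
compound 2, `CCN(CC)Cc1cc(/C=C2\Oc3cc(OC)c(OC)cc3C2=O)cc(CN(CC)CC)c1O`: 32.7%
compound 3, `COc1cc2c(cc1OC)C(=O)/C(=C/c1ccc(CN3CCN(Cc4ccccc4)CC3)c(O)c1)O2`: 6.9%

The read-out is an assay on cells for inhibition of Amine oxidase [flavin-containing] B (Homo sapiens), read by fluorescence, with a stated time of 30 min, tested at 10 uM; a lower number here means less inhibition, a higher number more inhibition at the concentration tested (going by the name of the read-out). Compound 1 gives 17.8% in this assay and stands second highest of the three numbers. Its nearest neighbour is compound 3, with 6.9%, a number lower than that of compound 1 by more than the scatter. The furthest is compound 2, with 32.7%, higher than compound 1 by more than the scatter. No two of these three fall within the scatter of each other.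

The next compound is compound 4, `CCN(CC)Cc1ccc(/C=C2\Oc3cc(OC)c(OC)cc3C2=O)cc1O`, not yet measured in this assay. It differs from compound 1 in one place: diethylamino in place of benzyl(methyl)amino on a saturated chain carbon bound to an aromatic carbon. Within the data shown here, nothing among the measured pairs shows this change alone, so no measured step can be quoted for it. What is available is compound 2, whose structure also carries diethylamino and which gives 32.7%, the highest number of the three.

For compound 4 the expectation is a modest rise over compound 1, a step of a number 5.2 percentage points higher from compound 1 to compound 4 (within the scatter), which may not exceed the scatter. Compound 4 is estimated at 23% in this assay, within 9% to 38%.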

Compound 4, a percentage reported as inhibition, at one concentration (the size of the read-out at that concentration, not a potency): 7.2%
Compound 4: middle estimate off by 15.8 percentage points, on the high side, and the stated range ends above it.
By their numbers in this assay, from the lowest: compounds 3 and 4 (each within the scatter of the next); then compound 1; then compound 2.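

Diethylamino in place of benzyl(methyl)amino on a saturated chain carbon bound to an aromatic carbon gives, in this assay, a number 10.6 percentage points lower from compound 1 to compound 4 (beyond the scatter), the first single-place step in this series. The position therefore responds to the amine it carries, and the benzyl(methyl)amino group gives the higher number of this pair. Diethylamino alone does not bring the number seen for compound 2 at 32.7%, as compound 4 stands at 7.2%; nothing available accounts for the step.

This single step cannot separate the loss of the aromatic ring from the drop in heavy atoms, since both change together between the two amines. Dimethylamino, morpholine or pyrrolidine on the same saturated chain carbon would show whether the number follows the benzyl group specifically or varies more widely with the amine, and the shared core with a different amine at this place remains open in this assay.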